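A few compounds are considered here, and "the series" means these few. Any claim that something is new, unique, unknown or untested is made for them only; others in the source may bear on it.

The measured compounds and their values in a functional assay on A549 cells (Homo sapiens) for antiproliferative activity, read by MTT assay, with a stated time of 72 h; on this read-out higher numbers stand for weaker inhibition and lower numbers for stronger inhibition:

compound 1, `CNC(=O)c1cc(Oc2ccc(NC(=O)c3cc4cccnc4n(-c4ccc(OC)cc4)c3=O)cc2)ccn1`, 3110 nM
compound 2, `CCNC(=O)c1cc(Oc2ccc(NC(=O)c3cc4cccnc4n(-c4ccc(F)cc4)c3=O)cc2)ccn1`, 120 nM
compound 3, `CCCNC(=O)c1cc(Oc2ccc(NC(=O)c3cc4cccnc4n(-c4ccc(F)cc4)c3=O)cc2)ccn1`, 62 nM

Compound 3 gives the lowest of the three numbers in this assay. Its nearest neighbour is compound 2, and the step of a 1.9-fold lower number from compound 2 to compound 3 (0.29 log units; within the scatter) lies within the scatter. Compound 1 stands far away, with a number well above that of compound 3, though the two structures differ in two places, so no single step accounts for that gap.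

Compound 4, `CCCNC(=O)c1cc(Oc2ccc(NC(=O)c3cc4cccnc4n(-c4ccc(OC)cc4)c3=O)cc2)ccn1`, is compound 3 with one change: methoxy in place of fluoro on an aromatic carbon, on an aromatic carbon of a six-membered aromatic ring of carbon only, para to a large group. Going by the values given here, no measured step isolates this change. Among the compounds with values here, the only compound carrying methoxy is compound 1, and its value in this assay is high, while the chain change from compound 2 to compound 3 was small. The values of compound 1 and compound 3 therefore suggest that much of their gap may follow the methoxy group. A clearly weaker result is expected for compound 4, with the step of a 24-fold higher number from compound 3 to compound 4 (1.38 log units; beyond the scatter) in this assay. The estimate for compound 4 is 1500 nM, within a range of 400 nM to 5000 nM.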

Compound 4, half-maximal inhibitory concentration: 820 nM
For compound 4 the middle estimate is 1.8-fold (0.26 log units) above the measured one; the measured number falls inside the stated range.
By their numbers in this assay, from the lowest: compounds 3 and 2 (each within the scatter of the next); then compound 4; then compound 1.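

In this assay, the change on the aromatic carbon, para to a large group, can now be read directly: methoxy in place of fluoro gives a 13-fold higher number from compound 3 to compound 4 (1.12 log units; beyond the scatter), a large step. With methoxy held constant, ethyl in place of hydrogen on the saturated chain carbon bound to the amide-type nitrogen gives a 3.8-fold lower number from compound 1 to compound 4 (0.58 log units; beyond the scatter), a modest step, so both places affect the number, and the step at the aromatic carbon is the larger of the two. Nothing available here explains the size of either step.

The compounds shown leave open whether chloro, hydroxy or an amine on this aromatic carbon would give a number closer to that of fluoro or of methoxy. They also leave open whether a longer chain on the amide would change the number further with either group in place.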